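Compound 3: piperidine to methylpiperazine on the chain

The source may report more compounds than this note shows. Statements on the series, on what has been measured and on what is new or still open speak of the compounds shown alone.

In a functional assay on SH-SY5Y cells (Homo sapiens) for cytotoxicity, read by MTT assay, with a stated time of 72 h (on this read-out higher numbers stand for weaker inhibition and lower numbers for stronger inhibition), compound 1 `O=C1c2c[n+]([O-])c3ccccc3c2C(=O)c2c1c1ccccc1n2Cc1cn(C[C@H](O)CO)nn1` gives only a limit, > 1000 nM. Among the measured compounds shown here, compound 2 `O=C1c2c[n+]([O-])c3ccccc3c2C(=O)c2c1c1ccccc1n2CCCCN1CCCCC1` gives the only exact number, 230 nM. Compound 3 `CN1CCN(CCCn2c3c(c4ccccc42)C(=O)c2c[n+]([O-])c4ccccc4c2C3=O)CC1` differs from it by 4-methylpiperazin-1-yl in place of (piperidin-1-yl)methyl on a saturated chain carbon, three bonds along the chain from an aromatic nitrogen. For the measured compounds named here, the only measured step, an at least 4.3-fold lower number from compound 1 to compound 2 (0.63 log units; beyond the scatter), involves a different exchange and therefore bears on this change only weakly. No step beyond the scatter is expected in this assay, and the expected step is a 1.4-fold higher number from compound 2 to compound 3 (0.14 log units; within the scatter). For compound 3 the estimate is 320 nM, with an expected range of 110 nM to 950 nM.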

Compound 3, half-maximal inhibitory concentration: 560 nM
Compound 3: middle estimate off by 1.8-fold (0.24 log units), on the low side, within the range that was stated.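

Between two exact numbers, this position is not indifferent to the exchange: in this assay there is a 2.4-fold higher number from compound 2 to compound 3 (0.39 log units; beyond the scatter), with the heavy-atom count unchanged. The other new step is an at least 1.7-fold lower number from compound 1 to compound 3 (0.25 log units; that floor lies within the scatter), and it reads only as a floor. Compound 1 gives a limit, not a number: the limit of > 1000 nM in this assay, at which 1 of the 3 values shown sits.

Read one bond further out, the exchange is 4-(piperidin-1-yl)butyl to 3-(4-methylpiperazin-1-yl)propyl, so chain and ring change together. Going by these compounds, a 3-(piperidin-1-yl)propyl or 4-(4-methylpiperazin-1-yl)butyl group would separate the two, and a morpholine at the chain end remains open.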